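The source may report more compounds than this note shows. Statements on the series, on what has been measured and on what is new or still open speak of the compounds shown alone.

Working notes on the three-compound series sharing one core. Compound 1 `C(=N/c1sc2c(c1-c1nc3ccccc3s1)CCCC2)\c1ccccc1` carries an unsubstituted phenyl on the imine; in an ADME assay on HepG2 cells (Homo sapiens) for cytotoxicity, read by MTT assay, with a stated time of 72 h (on this read-out higher numbers stand for lower toxicity in this test and lower numbers for higher toxicity in this test), compound 1 gives 308 ug/mL. Compound 2 `Fc1ccccc1/C=N/c1sc2c(c1-c1nc3ccccc3s1)CCCC2` adds a fluoro, and in this assay compound 2 gives 398 ug/mL. Compound 3 `Clc1ccccc1/C=N/c1sc2c(c1-c1nc3ccccc3s1)CCCC2` adds a chloro instead, and in this assay compound 3 gives 370 ug/mL. All three numbers sit inside the usual scatter of one another: a 1.3-fold higher number from compound 1 to compound 2 (0.11 log units; within the scatter), a 1.2-fold higher number from compound 1 to compound 3 (0.08 log units; within the scatter) and a 1.1-fold lower number from compound 2 to compound 3 (0.03 log units; within the scatter). Among the compounds with values here, compound 3 therefore stands indistinguishably from both neighbours on the numbers so far; nothing separates the three halogen variations in this read-out.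

Compound 4 `O=[N+]([O-])c1ccccc1/C=N/c1sc2c(c1-c1nc3ccccc3s1)CCCC2` is the next member. The change from compound 3 is nitro in place of chloro on an aromatic carbon. The measured steps that bear on it are the three above, each an exchange at the same aromatic carbon, and none moved the number beyond scatter. On that basis no step beyond scatter is expected for compound 4 in this assay, in either direction; the expected step is a 1.0-fold lower number from compound 3 to compound 4 (0.01 log units; within the scatter). Compound 4 is accordingly estimated at 360 ug/mL, with a range from 200 ug/mL to 650 ug/mL.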

Compound 4, half-maximal cytotoxic concentration: 393 ug/mL
The estimate for compound 4 lay 1.1-fold (0.04 log units) below the measured number; the range from low to high includes it.
By their numbers in this assay, from the lowest: compounds 1, 3, 4 and 2 (each within the scatter of the next).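

Within the data shown here, at this aromatic carbon, ortho to a large group, nitro is the first replacement that is not a single atom: it brings three heavy atoms and two hydrogen-bond acceptors where chloro has one heavy atom and none. Even so, the number in this assay does not separate compound 4 from the others, with a 1.1-fold higher number from compound 3 to compound 4 (0.03 log units; within the scatter) and a 1.0-fold lower number from compound 2 to compound 4 (0.01 log units; within the scatter) and a 1.3-fold higher number from compound 1 to compound 4 (0.11 log units; within the scatter) as the steps, so the flat picture seen for hydrogen, fluoro and chloro now extends to 2-nitrophenyl across these four compounds. Nothing available on these compounds explains why this read-out stays flat across the exchanges.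

Whether any group at this carbon can move the number beyond the scatter remains open, since an amine, a carboxylic acid or a longer chain such as butyl could behave differently from the groups shown here. On these data alone, it is also open whether fluoro, chloro or nitro would give the same flat result on another carbon of the phenyl ring, or whether the shared core alone sets the level of these numbers.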